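Notes on the amine side chain of compound 1

The source may report more compounds than this note shows. Statements on the series, on what has been measured and on what is new or still open speak of the compounds shown alone.

Compound 1 `CNCCNc1cc2c(cc1F)c(=O)c(C(=O)O)cn2Cc1ccc(-c2ccccc2)cc1` gives > 200000 nM in an assay on isolated protein for inhibition of DNA topoisomerase 1 (Homo sapiens), with a stated time of 15 min; a higher number here means a weaker inhibitor, a lower number a stronger inhibitor; this value is a limit of the assay.
Compound 2 `CNCCNc1c(F)cc2c(=O)c(C(=O)O)cn(Cc3ccc(-c4ccccc4)cc3)c2c1OC` gives > 200000 nM in this assay; this value is also a limit.

Among the compounds with values here, compound 1 therefore stands only at a limit in this assay, and the one other value shown is a limit as well (the limit of > 200000 nM in this assay, at which 2 of the 2 values shown sit). Within the data shown here, the single measured step, a step that the two limits leave unreadable from compound 1 to compound 2, a methoxy in place of hydrogen on an aromatic carbon, cannot be read in size or direction from these two limits.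

Compound 3 `CNC[C@@H]1CCN(c2cc3c(cc2F)c(=O)c(C(=O)O)cn3Cc2ccc(-c3ccccc3)cc2)C1` is not yet measured. It differs from compound 1 by 3-((methylamino)methyl)pyrrolidin-1-yl in place of (2-(methylamino)ethyl)amino on an aromatic carbon. No measured step touches this part of the structure, so nothing among the shown compounds speaks for or against a change beyond the scatter; the only information is that both measured compounds sit at the limit.

Compound 3 is therefore expected to sit near the same limit, with an estimated value of 200000 nM (range 50000 nM to 1000000 nM). The estimated step of a number no higher from compound 1 to compound 3 (the limit leaves the size open) is expected to be none beyond the scatter.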

Compound 3, half-maximal inhibitory concentration: 168000 nM
For compound 3 the middle estimate is 1.2-fold (0.08 log units) above the measured one; the measured number falls inside the stated range.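

In this assay, within the data shown here, compound 3 gives 168000 nM, the first value that is a number and not a limit, so this side chain on the shared core can be placed on the scale. Putting 3-((methylamino)methyl)pyrrolidin-1-yl in place of (2-(methylamino)ethyl)amino, on the aromatic carbon ortho to a fluoro group, gives an at least 1.1-fold lower number from compound 1 to compound 3 (0.07 log units; that floor lies within the scatter), and this floor shows no change beyond the scatter, while the full size of the step stays unreadable, as does the step to the methoxy compound 2. The five-membered ring with its defined stereocentre therefore leaves the series at the weak end of the scale, with the other compounds at a limit: the limit of > 200000 nM in this assay, at which 2 of the 3 values shown sit.

From the compounds shown here alone, it remains open whether a piperazin-1-yl ring, a primary amine on the pyrrolidine or a longer chain at this position would give a number clearly separated from that of compound 3. Going by these compounds, the opposite configuration at the stereocentre and a primary amide in place of the carboxylic acid are equally open.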